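This account rests on a few compounds, and the source may have more. Where it says the series, first, only, none or still open, it means among the compounds named here.

Compound 1 `O=S(=O)(Nc1ccc(-c2nc3ccccc3o2)cc1)c1cccc(O)c1`: in an assay on isolated protein for inhibition of malate dehydrogenase, mitochondrial (Sus scrofa), with stated times of 45 min and 30 min (a higher number here means a weaker inhibitor, a lower number a stronger inhibitor), compound 1 gives > 63000 nM, which is a limit of the assay.
Compound 2 `O=S(=O)(Nc1ccc(-c2nc3ccccc3o2)cc1)c1cccs1`: in this assay compound 2 gives > 63000 nM, again a limit.
Compound 3 `O=S(=O)(Nc1ccc2oc(-c3ccccc3)nc2c1)c1cccc(O)c1`: in this assay compound 3 gives > 63000 nM, also a limit.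

The change from compound 1 to compound 2 is thiophen-2-yl in place of 3-hydroxyphenyl on a sulfonyl sulfur, and the step it made, a step that the two limits leave unreadable from compound 1 to compound 2, cannot be read from two limits. The cores of compound 1 and compound 3 differ, but that difference is not broken down here. Compound 4 `O=S(=O)(Nc1ccc2oc(-c3ccccc3)nc2c1)c1cccs1` carries the same change on the core of compound 3: thiophen-2-yl in place of 3-hydroxyphenyl on a sulfonyl sulfur. The step expected is a step that the limit leaves unreadable from compound 3 to compound 4, resting on the measured step that the two limits leave unreadable from compound 1 to compound 2 and on the fact that all three values sit at the limit of > 63000 nM in this assay, at which 3 of the 3 values shown sit. Compound 4 is expected at 100000 nM, likely between 40000 nM and 300000 nM, because every value shown sits at the limit of > 63000 nM in this assay, at which 3 of the 3 values shown sit.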

Compound 4, half-maximal inhibitory concentration: > 63000 nM
Compound 4: only a limit was reported; the forecaster's own chance of this, stated with the estimate: 85%; the middle value is on the limit's open side.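

No step can be read from compound 3 to compound 4, as both values are limits: the limit of > 63000 nM in this assay, at which 4 of the 4 values shown sit. The compounds shown leave open how strongly compound 1, compound 2, compound 3 or compound 4 inhibits in this assay, and whether thiophen-2-yl in place of 3-hydroxyphenyl changes anything.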